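Cytotoxicity in the biaryl amide acid series: compound 4

A few compounds are considered here, and "the series" means these few. Any claim that something is new, unique, unknown or untested is made for them only; others in the source may bear on it.

Compound 3 `CC(C)N(Cc1cccc(OCCCCCC(=O)O)c1)C(=O)c1ccc(-c2ccc3[nH]ccc3c2)cc1` is the point of departure. In an ADME assay on Raji cells (Homo sapiens) for cytotoxicity, read by CellTiter-Glo and resazurin assay, with a stated time of 72 h (a higher number here means that more compound is needed for the effect, a lower number that less compound is needed), compound 3 gives > 26000 nM, which is a limit and not a number. Compound 1 `CC(C)N(Cc1cccc(OCCCCCC(=O)O)c1)C(=O)c1ccc(-c2cccc(-c3ccccc3)c2)cc1` gives > 26000 nM in this assay, also a limit. Compound 2 `CC(=O)c1cccc(-c2ccc(C(=O)N(Cc3cccc(OCCCCCC(=O)O)c3)C(C)C)cc2)c1` gives > 26000 nM in this assay, again a limit. The evidence across these three compounds is the limit of > 26000 nM in this assay, at which 3 of the 3 values shown sit. The steps a step that the two limits leave unreadable from compound 1 to compound 2, a step that the two limits leave unreadable from compound 1 to compound 3 and a step that the two limits leave unreadable from compound 2 to compound 3 are therefore all of unreadable size, and the exchange of one ring group for another on the aromatic carbon para to a large group has so far left no readable mark in this assay. Compound 4 `CCOc1cccc(-c2ccc(C(=O)N(Cc3cccc(OCCCCCC(=O)O)c3)C(C)C)cc2)c1` differs from compound 3 by 3-ethoxyphenyl in place of 1H-indol-5-yl on an aromatic carbon. For the measured compounds named here, the steps that bear on this change are the three just named, none of them readable. On this basis no step beyond the scatter is expected, and the estimated step that the limit leaves unreadable from compound 3 to compound 4 is centred on no change. Compound 4 is expected to give 40000 nM in this assay, with a range from 15000 nM to 120000 nM, most probably again reported only as a limit.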

Compound 4, half-maximal effective concentration: > 20800 nM
Compound 4 was reported as a limit; the forecaster's own chance of this, stated with the estimate: 85%; the middle value is on the limit's open side.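

Compound 4 gives > 20800 nM in this assay, which is a limit and not a number. Its steps from compound 1, compound 2 and compound 3 cannot be read. Still open, from the compounds shown here alone, is whether the aryl groups on these four compounds differ at all in this assay.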